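A few compounds are considered here, and "the series" means these few. Any claim that something is new, unique, unknown or untested is made for them only; others in the source may bear on it.

Compound 1, `CC(C)(C)OC(=O)N1CCC(Oc2cccc3c2ccn3-c2ccc(S(C)(=O)=O)cc2)CC1`: in a functional assay on CHO-K1 cells for agonist activity at Glucose-dependent insulinotropic receptor (Homo sapiens), read by a luciferase reporter, with a stated time of 5 h (a higher number here means that more compound is needed for the effect, a lower number that less compound is needed), compound 1 gives 631 nM.
Compound 2, `CC(C)OC(=O)N1CCC(Oc2ncnc3c2CCN3c2ccc(-c3cccn3C)cc2F)CC1`: in this assay compound 2 gives 158 nM.
Compound 3, `CC(C)(C)OC(=O)N1CCC(Oc2ncnc3c2CCN3c2ccc(S(C)(=O)=O)cc2F)CC1`: in this assay compound 3 gives 20 nM.

Among these three, compound 3 stands lowest, meaning it needs the least compound for the effect. Its nearest neighbour is compound 2, and even that gap lies beyond the usual scatter of repeated measurements; compound 1 lies further still. Compounds 1, 2 and 3 differ from one another in more than one place, so none of their differences isolates a single change.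

Compound 4, `CC(C)(C)COC(=O)N1CCC(Oc2ncnc3c2CCN3c2ccc(S(C)(=O)=O)cc2F)CC1`, is the next step. It differs from compound 3 only by neopentyl in place of tert-butyl on an oxygen next to a carbonyl group. For the measured compounds named here, no measured pair shows this change on its own, so the expectation rests on the change being small and confined to the chain on the oxygen next to the carbonyl group. A step of modest size is expected, if any, most likely a slight move toward needing more compound, and it may well stay within the scatter. The step expected from compound 3 to compound 4 in this assay is a 1.6-fold higher number from compound 3 to compound 4 (0.20 log units; within the scatter). Compound 4 is estimated to give 32 nM, with a range from 10 nM to 100 nM.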

Compound 4, half-maximal effective concentration: 39.8 nM
Compound 4: middle estimate off by 1.2-fold (0.09 log units), on the low side, within the range that was stated.
By their numbers in this assay, from the lowest: compounds 3 and 4 (each within the scatter of the next); then compound 2; then compound 1.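

For the compounds shown here, compounds 3 and 4 form the first pair here that differs in one place only, so the exchange of tert-butyl for neopentyl on an oxygen next to a carbonyl group can be read on its own: in this assay the step is a 2.0-fold higher number from compound 3 to compound 4 (0.30 log units; within the scatter). At this place, then, the two chains cannot be told apart in this assay, and the good reading of compound 3 does not depend on tert-butyl in particular, though this rests on a single pair. Nothing available here explains why the two chains read alike.

Going by these compounds, how far this tolerance extends remains open: a longer chain such as n-hexyl, a ring such as cyclohexyl, or a chain carrying an amine could behave quite differently. Whether the same exchange would read alike on another core is also unknown.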